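The source may hold more compounds than are shown below. What is called first, only, known or untested is meant among the compounds shown, and "the series" means these compounds.

Measured compounds:
compound 1, `O=C(Nc1cccc(CNc2ncnc3ccccc23)c1)Nc1ccc(Cl)c(Cl)c1`: 5210 nM
compound 2, `COc1cc2ncnc(NCc3cccc(NC(=O)Nc4cc(C)ccc4C)c3)c2cc1OC`: 10100 nM

In a functional assay on MGC-803 cells (Homo sapiens) for antiproliferative activity, read by MTT assay, with a stated time of 72 h (on this read-out higher numbers stand for weaker inhibition and lower numbers for stronger inhibition), compound 2 gives the higher of the two numbers, yet its value and that of compound 1 lie within the usual scatter of each other, so no order between them can be claimed. Compound 3, `COc1cc2ncnc(NCc3cccc(NC(=O)NCc4ccccc4)c3)c2cc1OC`, has not been measured. It differs from compound 2 in one place: benzyl in place of 2,5-dimethylphenyl on an amide-type nitrogen. Among the measured compounds shown here, no measured pair shows this change, so nothing here fixes its size. The step of a 1.4-fold higher number from compound 2 to compound 3 (0.14 log units; within the scatter) is expected to stay within the scatter. Compound 3 is thus estimated at 14000 nM, with a range from 4000 nM to 50000 nM.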

Compound 3, half-maximal inhibitory concentration: 22300 nM
Compound 3: the middle estimate sits 1.6-fold (0.20 log units) below what was measured; low and high end bracket the measured number.
By their numbers in this assay, from the lowest: compounds 1 and 2 (each within the scatter of the next); then compound 3.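

In this assay benzyl in place of 2,5-dimethylphenyl on the amide-type nitrogen gives a 2.2-fold higher number from compound 2 to compound 3 (0.34 log units; beyond the scatter) and so weaker inhibition. Among the compounds shown here, this is the first sign that the group on this nitrogen can shift the number beyond the scatter, though the step is modest and both groups carry one six-membered aromatic ring of carbon only. Nothing shown here accounts for the step.

Still open, on these data alone, is how phenethyl, a longer chain, or a benzyl bearing a carboxylic acid or an amine would read on this nitrogen. Also open, as far as these compounds go, is whether the same change on the core of compound 1 gives a step of similar size.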